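The compounds below may be only part of what the source reports. "The series", "measured", "known", "first", "only" and "open" are said of these compounds alone.

Working notes on the triply fluorinated anilide urea series, cytotoxicity read-out.

Compound 2 `O=C1NC(c2ccccc2)CN1c1cnn2c1CN(C(=O)Nc1cc(F)c(F)c(F)c1)C(C1CC1)C2` holds the lowest of the two numbers in a toxicity assay on HepG2 2.2.15 cells (Homo sapiens) for cytotoxicity, read by CellTiter-Glo (on this read-out higher numbers stand for lower toxicity in this test and lower numbers for higher toxicity in this test), at 38500 nM. The nearest number belongs to compound 1 `CC1CN(C(=O)Nc2cc(F)c(F)c(F)c2)Cc2c(N3CC(C#N)CC3=O)cnn21`, which in this assay gives 115000 nM, a gap that lies beyond the usual scatter. Compound 3 `CC1(C)CN(C(=O)Nc2cc(F)c(F)c(F)c2)Cc2c(N3CC(C#N)CC3=O)cnn21` gives in this assay only a limit, > 200000 nM, and no number. Among the measured compounds shown here, this is the one compound sitting at the limit of > 200000 nM in this assay, at which 1 of the 3 values shown sits.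

For the measured compounds named here, the only measured step, an at least 1.7-fold higher number from compound 1 to compound 3 (0.24 log units; that floor lies within the scatter), concerns a methyl on a saturated ring carbon of the shared core and does not touch the substituent that changes here.

Compound 4 `Cc1nc(C2CC(=O)N(c3cnn4c3CN(C(=O)Nc3cc(F)c(F)c(F)c3)C(C3CC3)C4)C2)no1` differs from compound 2 by 4-(5-methyl-1,2,4-oxadiazol-3-yl)-2-oxopyrrolidin-1-yl in place of 2-oxo-4-phenylimidazolidin-1-yl on an aromatic carbon. Going by the values given here, no measured step bears directly on this exchange. What the numbers do show is that compound 1 and compound 3, both carrying a 2-oxopyrrolidin-1-yl substituent at this position, sit at the higher end of the range, while compound 2 with the phenyl-bearing imidazolidinone sits lowest.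

On that basis compound 4 is expected to move toward the numbers of compound 1 and compound 3, an upward step of a 2.6-fold higher number from compound 2 to compound 4 (0.41 log units; beyond the scatter). The estimate for compound 4 in this assay is 100000 nM, with a range from 35000 nM to 200000 nM.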

Compound 4, half-maximal cytotoxic concentration: > 200000 nM
Compound 4 was reported as a limit; the forecaster's own chance of this, stated with the estimate: 30%; at least 2.0-fold (0.30 log units) between middle value and limit.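

Among the compounds shown here, until now no measured step touched the substituent on this aromatic carbon of the five-membered aromatic ring. The exchange gives an at least 5.1-fold higher number from compound 2 to compound 4 (0.71 log units; beyond the scatter), which shows that in this assay a change at this position alone can move the reading beyond the scatter. Compound 4 gives a limit and not a number, and it is the second compound found there: the limit of > 200000 nM in this assay, at which 2 of the 4 values shown sit.

The exchange also changes several features at once: a six-membered aromatic ring of carbon only gives way to a five-membered aromatic ring with 3 hetero atoms, the five-membered non-aromatic ring changes, and the hydrogen-bond donor of the leaving group goes, and the step cannot be assigned to any one of these.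

From the compounds shown here alone, it remains open whether the lower number of compound 2 follows from its phenyl or from its imidazolidinone ring, and a phenyl carried directly on the 2-oxopyrrolidin-1-yl ring would separate the two. Also open, going by these compounds, is how a carboxylic acid or an amine in place of the 5-methyl-1,2,4-oxadiazol-3-yl group would read in this assay.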